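A few compounds are considered here, and "the series" means these few. Any claim that something is new, unique, unknown or untested is made for them only; others in the source may bear on it.

Three measured compounds share one core and differ only in the group on a carbonyl carbon. In an assay on microsomes from liver for inhibition of 3-hydroxy-3-methylglutaryl-coenzyme A reductase (Rattus norvegicus) (a lower number here means a stronger inhibitor, a higher number a weaker inhibitor), compound 1 `CCN(Cc1ccccc1)C(=O)c1nn(-c2ccc(F)cc2)c(OC[C@@H](O)C[C@@H](O)CC(=O)O)c1C(C)C` gives 14 nM. In this assay compound 2 `CC(C)c1c(C(=O)NCC2CCCCC2)nn(-c2ccc(F)cc2)c1OC[C@@H](O)C[C@@H](O)CC(=O)O` gives 17 nM, and compound 3 `CC(C)c1c(C(=O)N2CCCC2c2ccccc2)nn(-c2ccc(F)cc2)c1OC[C@@H](O)C[C@@H](O)CC(=O)O` gives 14 nM. Compound 3 stands level with compound 1, the two together the lowest of the three numbers, and every step between them stays within the scatter: a 1.2-fold higher number from compound 1 to compound 2 (0.08 log units; within the scatter), no change at the digits printed from compound 1 to compound 3 (within the scatter), a 1.2-fold lower number from compound 2 to compound 3 (0.08 log units; within the scatter). Compound 4 `Cc1cccc(CNC(=O)c2nn(-c3ccc(F)cc3)c(OC[C@@H](O)C[C@@H](O)CC(=O)O)c2C(C)C)c1` changes the same place: (3-methylbenzyl)amino in place of 2-phenylpyrrolidin-1-yl on a carbonyl carbon. Because three exchanges at this carbonyl carbon gave no change at the digits printed from compound 1 to compound 3 (within the scatter) and a 1.2-fold lower number from compound 2 to compound 3 (0.08 log units; within the scatter), no step beyond the scatter is expected here either. For compound 4 in this assay the estimate is 14 nM, ranging from 7 nM to 28 nM, which is expected to mean no change at the digits printed from compound 3 to compound 4 (within the scatter).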

Compound 4, half-maximal inhibitory concentration: 4.9 nM
Estimate against measurement, compound 4: 2.9-fold (0.46 log units) above, and the stated range ends above it.
By their numbers in this assay, from the lowest: compound 4; then compounds 1, 3 and 2 (each within the scatter of the next).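

Among the compounds shown here, the group on this carbonyl carbon can move the number after all: (3-methylbenzyl)amino gives a 2.9-fold lower number from compound 3 to compound 4 (0.46 log units; beyond the scatter) and a 2.9-fold lower number from compound 1 to compound 4 (0.46 log units; beyond the scatter) as the first steps here beyond the scatter. Compounds 2 and 4 both keep the amide hydrogen, yet 3-methylphenyl in place of cyclohexyl still gives a 3.5-fold lower number from compound 2 to compound 4 (0.54 log units; beyond the scatter) so that hydrogen alone does not set the number. Nothing available here explains the lower number.

On these data alone, whether the methyl contributes remains open, as a plain benzylamino group would test. A (3-chlorobenzyl)amino group would show whether another atom can take its place.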